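From 3-carboxypyrrolidin-1-yl to 3-hydroxypyrrolidin-1-yl on the shared core

The source may report more compounds than this note shows. Statements on the series, on what has been measured and on what is new or still open speak of the compounds shown alone.

Measured in a functional assay on HeLa cells (Homo sapiens) for antiproliferative activity, read by CCK-8 assay, with a stated time of 48 h; a higher number here means a weaker inhibitor, a lower number a stronger inhibitor:
Compound 1 `COc1ccc(/C=C\c2cc(OC)c(OC)c(OC)c2)cc1OCc1ccc(C=O)cc1`: 4800 nM
Compound 2 `COc1ccc(/C=C\c2cc(OC)c(OC)c(OC)c2)cc1OCc1ccc(CN2CCCCC2C(=O)NCCNC(=O)OC(C)(C)C)cc1`: 2000 nM
Compound 3 `COc1ccc(/C=C\c2cc(OC)c(OC)c(OC)c2)cc1OCc1ccc(CN2CC[C@H](C(=O)O)C2)cc1`: > 10000 nM (a limit of the assay, not a number)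

Compound 3 stands at the limit of > 10000 nM in this assay, at which 1 of the 3 values shown sits. This is a limit, so compound 3 has no exact place on the scale.

Compound 4 `COc1ccc(/C=C\c2cc(OC)c(OC)c(OC)c2)cc1OCc1ccc(CN2CC[C@@H](O)C2)cc1` keeps the shared core and differs from compound 3 in one group: 3-hydroxypyrrolidin-1-yl in place of 3-carboxypyrrolidin-1-yl on a saturated chain carbon bound to an aromatic carbon. Here 3-hydroxypyrrolidin-1-yl comes in place of 3-carboxypyrrolidin-1-yl, on a saturated chain carbon bound to an aromatic carbon.

Within the data shown here, one measured step bears on this change: an at least 2.0-fold higher number from compound 1 to compound 3 (0.31 log units; beyond the scatter), with (3-carboxypyrrolidin-1-yl)methyl in place of formyl on an aromatic carbon. On these data alone, its full size is unknown, as it ends at a limit. Compound 3 alone carries the 3-carboxypyrrolidin-1-yl group, and that group leaves in compound 4. A lower number in this assay is therefore expected, moving toward compound 1 at 4800 nM and compound 2 at 2000 nM. Among the measured compounds shown here, no measured compound carries the 3-hydroxypyrrolidin-1-yl group, so the range stays wide.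

The expected change is an at least 2.8-fold lower number from compound 3 to compound 4 (0.45 log units; beyond the scatter).

For compound 4 the estimated value is 3500 nM, with an expected range of 1000 nM to 10000 nM.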

Compound 4, half-maximal inhibitory concentration: > 10000 nM
Compound 4: no number, only a limit; the forecaster's own chance of this, stated with the estimate: 20%; middle value at least 2.8-fold (0.45 log units) away from the limit.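

In this assay, putting (3-hydroxypyrrolidin-1-yl)methyl in place of formyl gives an at least 2.0-fold higher number from compound 1 to compound 4 (0.31 log units; beyond the scatter), so the loss of activity seen with compound 3 does not depend on the carboxylic acid alone. The step from compound 3 to compound 4 cannot be read, since neither compound has a number and both end at the same limit of the assay: the limit of > 10000 nM in this assay, at which 2 of the 4 values shown sit.

On these data alone, removing the 3-carboxypyrrolidin-1-yl group from this saturated chain carbon therefore brought no measurable gain with 3-hydroxypyrrolidin-1-yl in its place, although whether the two groups truly match or differ stays unknown.

Still open, as far as these compounds go, is whether a different group on this saturated chain carbon, such as dimethylamino or a morpholine ring, would bring the value back under the limit and give a real number to compare. Also open, from the compounds shown here alone, is how weak compound 3 and compound 4 really are, and whether the mirror-image form of the 3-hydroxypyrrolidin-1-yl group, with its one defined stereocentre reversed, would behave any differently.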